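Benzofuranyl in place of iodo on a nucleoside core

The compounds below may be only part of what the source reports. "The series", "measured", "known", "first", "only" and "open" are said of these compounds alone.

Measured compounds:
- compound 1 `COc1ncnc2c1c(I)cn2[C@@H]1O[C@H](CO)[C@@H](O)[C@H]1O`: 63000 nM
- compound 2 `CNc1ncnc2c1c(-c1ccsc1)cn2[C@@H]1O[C@H](CO)[C@@H](O)[C@H]1O`: > 100000 nM
- compound 3 `CNc1ncnc2c1c(-c1ccccc1)cn2[C@@H]1O[C@H](CO)[C@@H](O)[C@H]1O`: > 100000 nM

Within the data shown here, in an ADME assay on MRC5 cells (Homo sapiens), read by MTT assay, with a stated time of 72 h (on this read-out lower numbers stand for stronger inhibition and higher numbers for weaker inhibition), compound 1 gives 63000 nM, the only number among the three values shown. For compound 2 the assay reports only a limit, > 100000 nM. For compound 3 it likewise reports only a limit, > 100000 nM. The step that the two limits leave unreadable from compound 2 to compound 3 therefore cannot be read in size. Both of these compounds carry an aromatic group at the position where compound 1 carries iodo, and both sit at the limit (the limit of > 100000 nM in this assay, at which 2 of the 3 values shown sit).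

Compound 4 `COc1ncnc2c1c(-c1cc3ccccc3o1)cn2[C@@H]1O[C@H](CO)[C@@H](O)[C@H]1O` differs from compound 1 by 1-benzofuran-2-yl in place of iodo on an aromatic carbon. Among the measured compounds shown here, no measured step covers this exact change; the two compounds with an aromatic group at that position, compound 2 and compound 3, both end at the limit, which points toward weaker inhibition rather than stronger. The step from compound 1 is expected to be a 1.9-fold higher number from compound 1 to compound 4 (0.28 log units; within the scatter), weakening beyond the scatter. Compound 4 is therefore estimated at 120000 nM, within 40000 nM to 400000 nM, with a fair chance that only a limit is reported.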

Compound 4, half-maximal inhibitory concentration: 65600 nM
Beside the measured number, compound 4's estimate is 1.8-fold (0.26 log units) above it, within the range that was stated.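

In this assay, replacing iodo with 1-benzofuran-2-yl gives a 1.0-fold higher number from compound 1 to compound 4 (0.02 log units; within the scatter), so on the core of compound 1 this position holds a group of nine heavy atoms and two aromatic rings in place of a single iodine with no readable shift in the number. Among these compounds, compound 4 also gives a real number rather than a limit, which makes this the first readable step at this position. The values for compound 2 and compound 3 are only limits, so the step between them cannot be read: the limit of > 100000 nM in this assay, at which 2 of the 4 values shown sit.

As far as these compounds go, whether phenyl or thiophen-3-yl in place of iodo on the core of compound 1 would also leave the number in place remains open. So does the outcome for an amine, a carboxylic acid or a longer alkyl chain on that same aromatic carbon.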